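The source may report more compounds than this note shows. Statements on the series, on what has been measured and on what is new or still open speak of the compounds shown alone.

Compound 2 `COC(=O)[C@@]1(C)CC[C@@H]2C3=C1CC[C@@H](C)[C@]3(C)Cc1c2[nH]c2c(Br)cccc12` carries the highest number of the two values measured in a functional assay on WiDr cells (Homo sapiens) for inhibition, read by sulforhodamine B assay, with a stated time of 48 h (a higher number here means a weaker inhibitor of growth, a lower number a stronger inhibitor of growth), so far: compound 2 gives 37000 nM, whereas the parent compound 1 `COC(=O)[C@@]1(C)CC[C@@H]2C3=C1CC[C@@H](C)[C@]3(C)Cc1c2[nH]c2ccccc12` gives 4000 nM. Going by the values given here, the only step yet measured, a 9.3-fold higher number from compound 1 to compound 2 (0.97 log units; beyond the scatter), is the one that bears here, since the halogen sits at the same place. Compound 3 `COC(=O)[C@@]1(C)CC[C@@H]2C3=C1CC[C@@H](C)[C@]3(C)Cc1c2[nH]c2c(Cl)cccc12` follows by the change (chloro in place of bromo on an aromatic carbon), chloro in place of bromo on an aromatic carbon. Because compound 2 sits at 37000 nM after the bromo step, a chloro at that place is expected to land between the two known values, and the step of a 1.9-fold lower number from compound 2 to compound 3 (0.27 log units; within the scatter) is estimated to be small. The expected value for compound 3 in this assay is 20000 nM, within 6000 nM to 60000 nM.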

Compound 3, concentration for 50% growth inhibition: 21000 nM
Compound 3: middle estimate off by 1.1-fold (0.02 log units), on the low side, and the stated range covers the measured number.
By their numbers in this assay, from the lowest: compound 1; then compounds 3 and 2 (each within the scatter of the next).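

In this assay the exchange of one halogen for the other does not separate the two compounds: a 1.8-fold lower number from compound 2 to compound 3 (0.25 log units; within the scatter). With chloro in place of hydrogen there is a 5.3-fold higher number from compound 1 to compound 3 (0.72 log units; beyond the scatter), so the higher number seen with bromo also appears with a second halogen at this place. No available evidence bears on what lies behind this.

The compounds shown leave open whether a non-halogen group at this place, such as methoxy or an amine, also gives a higher number than the hydrogen of compound 1, and whether either halogen behaves alike elsewhere on this ring.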